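The source may report more compounds than this note shows. Statements on the series, on what has been measured and on what is new or still open speak of the compounds shown alone.

In a physicochemical assay for solubility, read by HPLC (on this read-out lower numbers stand for lower solubility and higher numbers for higher solubility), compound 1 (`Cc1ccc([C@H](C(=O)N(C)C)N2C(=O)[C@@H](C3Cc4ccccc4C3)NC(=O)[C@H]2CC(C)C)cn1`) stands at > 236 ug/mL, which is a limit and not a number. Compound 2 (`Cc1ccc([C@H](C(=O)N2CCCC2)N2C(=O)[C@@H](C3Cc4ccccc4C3)NC(=O)[C@H]2CC(C)C)cn1`) gives 241 ug/mL, and compound 3 (`CC(C)C[C@@H]1C(=O)N[C@H](C2Cc3ccccc3C2)C(=O)N1[C@@H](C(=O)N(C)C)c1ccc(N(C)C)nc1`) gives 233 ug/mL. Compound 4 (`Cc1ccc([C@H](C(=O)N(C)C)N2C(=O)[C@@H](C3Cc4ccccc4C3)NC(=O)[C@H]2CC(C)(C)C)cn1`) differs from compound 1 by methyl in place of hydrogen on a saturated chain carbon bound to three saturated chain carbons, which turns isobutyl into neopentyl. Neither measured step alters the isobutyl group: one is a step that the limit leaves unreadable from compound 1 to compound 2, on a carbonyl carbon, and the other is an at least 1.0-fold lower number from compound 1 to compound 3 (0.00 log units; that floor lies within the scatter), on an aromatic carbon. Neither gives a size for this change, so no step beyond the scatter is expected in this assay. The expected step is an at least 1.1-fold lower number from compound 1 to compound 4 (0.07 log units; that floor lies within the scatter). For compound 4 the estimated value is 200 ug/mL, with an expected range of 100 ug/mL to 270 ug/mL.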

Compound 4, solubility: > 242 ug/mL
Compound 4: only a limit was reported; the forecaster's own chance of this, stated with the estimate: 30%; at least 1.2-fold (0.08 log units) between middle value and limit.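

In this assay, among these compounds, compound 1 and compound 4 are both reported only as limits, and no step between them can be read. The compounds shown leave open what size of step isobutyl to neopentyl gives in this assay.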